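The source may report more compounds than this note shows. Statements on the series, on what has been measured and on what is new or still open speak of the compounds shown alone.

In a functional assay on MCF7 cells (Homo sapiens) for antiproliferative activity, read by MTT assay, with a stated time of 48 h (on this read-out lower numbers stand for stronger inhibition and higher numbers for weaker inhibition), compound 1 (`CCn1c(C(=O)N(CCC#N)CCC#N)ccc1C(CC)(CC)c1ccc(OCCC(O)(CC)CC)c(C)c1`) gives > 50000 nM as its reading, a limit of the assay and not a number. Compound 2 (`C#CC(C)OC(=O)c1ccc(C(CC)(CC)c2ccc(OCCC(O)(CC)CC)c(C)c2)n1CC`) gives > 50000 nM as its reading, again a limit. For the measured compounds named here, compound 3 (`CCC(C)C(NC(=O)c1ccc(C(CC)(CC)c2ccc(OCCC(O)(CC)CC)c(C)c2)n1CC)C(=O)O`) gives 11300 nM as the only true number of the three. Two measured steps reach it, an at least 4.4-fold lower number from compound 1 to compound 3 (0.64 log units; beyond the scatter) and an at least 4.4-fold lower number from compound 2 to compound 3 (0.64 log units; beyond the scatter), and each brings in its (1-carboxy-2-methylbutyl)amino group. Compound 4 (`CCC(C)C(CO)NC(=O)c1ccc(C(CC)(CC)c2ccc(OCCC(O)(CC)CC)c(C)c2)n1CC`) has hydroxymethyl in place of carboxy on a saturated chain carbon bound to an amide-type nitrogen and a saturated chain carbon. Neither step tests this swap alone, so no change beyond the scatter is expected, and the estimated step is a 1.1-fold higher number from compound 3 to compound 4 (0.03 log units; within the scatter) in size. For compound 4 the estimated value is 12000 nM, with an expected range from 4000 nM to 40000 nM in this test.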

Compound 4, half-maximal inhibitory concentration: 29100 nM
Beside the measured number, compound 4's estimate is 2.4-fold (0.38 log units) below it, and the stated range covers the measured number.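

Swapping carboxy for hydroxymethyl on this saturated chain carbon gives a 2.6-fold higher number from compound 3 to compound 4 (0.41 log units; beyond the scatter), so the two groups are not interchangeable here, even though compound 4 keeps the rest of compound 3 unchanged. The other two steps are an at least 1.7-fold lower number from compound 2 to compound 4 (0.23 log units; that floor lies within the scatter) and an at least 1.7-fold lower number from compound 1 to compound 4 (0.23 log units; that floor lies within the scatter). They give only floors and no true sizes, because their starting compounds sit at a limit of the assay: the limit of > 50000 nM in this assay, at which 2 of the 4 values shown sit.

The compounds shown leave open how a methyl ester or a primary amide at this place would read. They also leave open whether the carboxy effect persists with a shorter chain than 2-methylbutyl.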